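The compounds below may be only part of what the source reports. "The series", "measured", "known", "first", "only" and "open" are said of these compounds alone.

Compound 1 `Cc1ccc(NC(=S)OCCNC(=O)C(C)(C)Oc2ccc(Cl)cc2)cc1` was examined in an ADME assay on H9c2 cells (Rattus norvegicus) for cytotoxicity, read by MTT assay, with a stated time of 48 h (on this read-out lower numbers stand for stronger inhibition and higher numbers for weaker inhibition), where compound 1 gives 771000 nM. Two other compounds were run in this assay: compound 2 `Cc1ccc(NC(=S)OCCNC(=O)c2cccnc2)cc1` gives 726000 nM, and compound 3 `NC(=S)c1ccc(OC(=O)c2cccnc2)cc1` gives 754000 nM. The number for compound 1 sits alongside those of compounds 2 and 3, with both gaps inside the usual scatter, so the three cannot be separated here. Compound 4 `CC(C)(Oc1ccc(Cl)cc1)C(=O)NCCOC(=S)Nc1ccccc1` has not yet been measured; it differs from compound 1 in one place (hydrogen in place of methyl on an aromatic carbon), the 4-methylphenyl becoming phenyl. Among the compounds with values here, no step between measured compounds is available to calibrate this change. In this assay compound 4 is expected near 750000 nM, between 400000 nM and 1400000 nM. The expected step is a 1.0-fold lower number from compound 1 to compound 4 (0.01 log units; within the scatter), nothing beyond the scatter.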

Compound 4, half-maximal inhibitory concentration: > 800000 nM
Compound 4 gave a limit, no number (the forecaster's own chance of this, stated with the estimate: 20%); middle value at least 1.0-fold (0.02 log units) from the limit.
By their numbers in this assay, from the lowest: compounds 2, 3 and 1 (each within the scatter of the next). At a limit, above all of these: compound 4.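

Compound 4 gives only a limit in this assay, not a number: the limit of > 800000 nM in this assay, at which 1 of the 4 values shown sits. Hydrogen in place of methyl on this aromatic carbon gives an at least 1.0-fold higher number from compound 1 to compound 4 (0.01 log units; that floor lies within the scatter), the first step read at this position. Losing the methyl therefore brings no move to a lower number, although the true size of the step cannot be read from a limit. From the compounds shown here alone, whether a methoxy group, a chlorine atom or an amine at this position would shift the number remains open, as does the effect of a longer chain there.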